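The source may hold more compounds than are shown below. What is called first, only, known or untested is meant among the compounds shown, and "the series" means these compounds.

Measured compounds in the series:

- compound 1, `O=S(=O)(Nc1ccc2oc(-c3ccccc3)nc2c1)c1ccccc1O`: 33000 nM
- compound 2, `O=S(=O)(Nc1ccc(-c2nc3ccccc3o2)cc1)c1ccccc1C(F)(F)F`: > 100000 nM
- compound 3, `O=S(=O)(Nc1ccc2oc(-c3ccccc3)nc2c1)c1cccc(C(F)(F)F)c1`: > 100000 nM

Notes. For the measured compounds named here, in an ADME assay on HEK293 cells (Homo sapiens) for cytotoxicity, read by resazurin assay, with a stated time of 48 h (a lower number here means that less compound is tolerated, a higher number that more compound is tolerated), compound 1 gives 33000 nM, and this is the only actual number in the set. For compound 2 the read-out is a limit of the assay, > 100000 nM, not a number. For compound 3 the read-out is likewise a limit, > 100000 nM. Going by the values given here, two of the three read-outs therefore sit at the limit of > 100000 nM in this assay, at which 2 of the 3 values shown sit, and compound 1 stands alone as the one compound with a determined half-maximal cytotoxic concentration.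

Compound 4, `O=S(=O)(Nc1ccc2oc(-c3ccccc3)nc2c1)c1cccs1`, has not been measured in this assay. It differs from compound 1 in one place: thiophen-2-yl in place of 2-hydroxyphenyl on a sulfonyl sulfur.

Among the compounds with values here, no step between measured compounds is available, so nothing in the data sizes this kind of change. Given that compounds 2 and 3 reach the limit while compound 1 sits below it, the step from compound 1 to compound 4 is expected to be small, within or just beyond the scatter, and if anything toward more compound tolerated, a 1.8-fold higher number from compound 1 to compound 4 (0.26 log units; within the scatter). For compound 4 the estimate is 60000 nM, with a range from 20000 nM to 150000 nM, and a fair chance that only a limit is reported.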

Compound 4, half-maximal cytotoxic concentration: 97000 nM
The estimate for compound 4 lay 1.6-fold (0.21 log units) below the measured number; low and high end bracket the measured number.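

The substituent on the sulfonyl sulfur now has a sized effect in this assay: thiophen-2-yl in place of 2-hydroxyphenyl gives a 2.9-fold higher number from compound 1 to compound 4 (0.47 log units; beyond the scatter). This single change removes the hydrogen-bond donor of 2-hydroxyphenyl and also replaces a six-membered aromatic ring of carbon only with a five-membered aromatic ring with a hetero atom, so the step cannot assign the shift to either difference. Compound 4 also leaves little readable room at the upper end of this read-out: the limit of > 100000 nM in this assay, at which 2 of the 4 values shown sit.

The compounds shown leave open whether the hydroxyl group alone carries the step, which an unsubstituted phenyl ring would help to separate from the change of ring. Also open, from the compounds shown here alone, is how an amine or a carboxylic acid on the same ring would read in this assay.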